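Desilylation of an alkynyl aminophenyl benzothiazole

A few compounds are considered here, and "the series" means these few. Any claim that something is new, unique, unknown or untested is made for them only; others in the source may bear on it.

The measured compounds:
- compound 1 `C[Si](C)(C)C#Cc1cc(-c2nc3cc(F)ccc3s2)ccc1N`: 160 nM
- compound 2 `C[Si](C)(C)C#Cc1cc(-c2nc3ccc(F)cc3s2)ccc1N`: 680 nM
- compound 3 `N#Cc1cc(-c2nc3ccccc3s2)ccc1N`: 580 nM

In a functional assay on MCF7 cells (Homo sapiens) for inhibition, with a stated time of 72 h (on this read-out higher numbers stand for weaker inhibition of growth and lower numbers for stronger inhibition of growth), compound 1 gives 160 nM, the lowest of the three numbers. The nearest value belongs to compound 3, whose number in this assay is 580 nM, and the furthest to compound 2, which gives 680 nM; both gaps to compound 1 lie beyond the usual scatter, so compound 1 stands as the strongest inhibitor of growth among the three.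

Compound 4 `C#Cc1cc(-c2nc3cc(F)ccc3s2)ccc1N` has not been measured. It differs from compound 1 by a hydrogen atom in place of a group of 4 heavy atoms (3 carbon, 1 silicon; no ring), on a triple-bonded carbon. No pair of measured compounds shares this change, so the size of the step is not known from the data shown; the only hint is that compound 3, which carries a nitrile where compound 1 carries the trimethylsilylethynyl group, gives a higher number. A moderate weakening, beyond the scatter but not large, is expected, as the step of a 2.2-fold higher number from compound 1 to compound 4 (0.34 log units; beyond the scatter) expresses. Compound 4 is therefore estimated at 350 nM in this assay, with a range from 100 nM to 1500 nM.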

Compound 4, concentration for 50% growth inhibition: 11 nM
Beside the measured number, compound 4's estimate is 32-fold (1.50 log units) above it, outside the stated range (below it).
By their numbers in this assay, from the lowest: compound 4; then compound 1; then compounds 3 and 2 (each within the scatter of the next).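

In this assay, going by these compounds alone, the exchange of the group of 4 heavy atoms (3 carbon, 1 silicon; no ring) for a hydrogen atom on the triple-bonded carbon gives a 15-fold lower number from compound 1 to compound 4 (1.16 log units; beyond the scatter) and is the first step at this place that can be read. It shows that the silicon-bearing group is not needed for growth inhibition in this pair, and that the number at this place responds strongly to what the triple-bonded carbon carries. Nothing shown here accounts for the size of this step.

Going by these compounds, whether other groups on that carbon, such as a methyl or a hydroxymethyl, would keep the low number of compound 4 stays open. Also open, on these data alone, is whether the same exchange would give a step of like size from compound 2, which carries the same silicon-bearing group.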